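Alkoxy branching and growth inhibition in the chalcone series

A few compounds are considered here, and "the series" means these few. Any claim that something is new, unique, unknown or untested is made for them only; others in the source may bear on it.

Compound 3 `CC(C)CCOc1cccc(O)c1C(=O)/C=C/c1ccc(O)cc1` is the starting point. In a functional assay on NUGC-3 cells (Homo sapiens) for antiproliferative activity, read by sulforhodamine B assay (on this read-out higher numbers stand for weaker inhibition of growth and lower numbers for stronger inhibition of growth), compound 3 gives 12400 nM, the highest of the two numbers shown. Compound 2 `O=C(/C=C/c1ccc(O)cc1)c1c(O)cccc1OCCC1CCCC1` gives 3200 nM. Compound 1 `CCCCCCOc1cccc(O)c1C(=O)/C=C/c1ccc(O)cc1` gives only a limit of the assay, > 30000 nM, as noted in the limit of > 30000 nM in this assay, at which 1 of the 3 values shown sits.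

Compound 4 `CCC(CC)COc1cccc(O)c1C(=O)/C=C/c1ccc(O)cc1` differs from compound 3 in one place: pentan-3-yl in place of isobutyl on a saturated chain carbon bound to an oxygen on an aromatic ring. The measured steps that bear on this are changes of the same chain end. From compound 1 to compound 2 the number fell an at least 9.3-fold lower number from compound 1 to compound 2 (0.97 log units; beyond the scatter), from compound 1 to compound 3 it fell an at least 2.4-fold lower number from compound 1 to compound 3 (0.38 log units; beyond the scatter), and from compound 2 to compound 3 it rose a 3.9-fold higher number from compound 2 to compound 3 (0.59 log units; beyond the scatter). Taken together, a bulkier or more branched group on this chain has gone with lower numbers in the measured cases, with compound 2 the lowest.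

Compound 4 is therefore expected to give a somewhat lower number than compound 3, a step of a 1.8-fold lower number from compound 3 to compound 4 (0.25 log units; within the scatter), near the edge of the scatter. The estimate for compound 4 is 7000 nM, with a range from 2500 nM to 20000 nM.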

Compound 4, concentration for 50% growth inhibition: 1960 nM
Compound 4: the middle estimate sits 3.6-fold (0.55 log units) above what was measured, and the stated range ends above it.
By their numbers in this assay, from the lowest: compounds 4 and 2 (each within the scatter of the next); then compound 3. At a limit, above all of these: compound 1.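

Moving from the isobutyl to the pentan-3-yl end, a step of a 6.3-fold lower number from compound 3 to compound 4 (0.80 log units; beyond the scatter), shows that an open branched chain end can bring a change at this place, with no ring needed. The comparison with the ring-bearing end, a 1.6-fold lower number from compound 2 to compound 4 (0.21 log units; within the scatter), leaves the cyclopentylmethyl and pentan-3-yl ends undistinguished. Pentan-3-yl in place of pentyl isolates branching from chain length, but an at least 15-fold lower number from compound 1 to compound 4 (1.18 log units; beyond the scatter) gives only a bound, since one end of the step is a limit of the assay: the limit of > 30000 nM in this assay, at which 1 of the 4 values shown sits.

Still open, on these data alone, is whether a larger branched end, such as cyclohexylmethyl or a longer 2-propylpentyl chain, would continue this trend or whether the trend stops at compounds 2 and 4. An amine at the chain end would show whether this place tolerates anything other than a hydrocarbon.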